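Sulfonamide nitrogen substituents on the shared core

The source may hold more compounds than are shown below. What is called first, only, known or untested is meant among the compounds shown, and "the series" means these compounds.

Compound 3 `CN(C)S(=O)(=O)c1ccc2c(c1)C(n1ccccc1=O)=CC(C)(C)O2` gives 16.2 nM in a functional assay with Rattus norvegicus as the target (on this read-out lower numbers stand for an effect already at smaller amounts and higher numbers for an effect only at larger amounts of compound), the lowest number of the three measured. Compound 1 `CCNS(=O)(=O)c1ccc2c(c1)C(n1ccccc1=O)=CC(C)(C)O2` gives 56.2 nM and compound 2 `CC1(C)C=C(n2ccccc2=O)c2cc(S(=O)(=O)NCCO)ccc2O1` gives 110 nM. The two steps onto the sulfonyl sulfur both lower the number: a 3.5-fold lower number from compound 1 to compound 3 (0.54 log units; beyond the scatter) and a 6.8-fold lower number from compound 2 to compound 3 (0.83 log units; beyond the scatter). The step of a 2.0-fold higher number from compound 1 to compound 2 (0.29 log units; within the scatter) stays within the scatter.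

Compound 4 `CN(c1ccccc1)S(=O)(=O)c1ccc2c(c1)C(n1ccccc1=O)=CC(C)(C)O2` differs from compound 3 by phenyl in place of methyl on a sulfonamide nitrogen. For the measured compounds named here, the measured steps concern only small chain groups on the sulfonamide nitrogen; none brings in a ring, so no measured step tells how a phenyl there reads in this assay. The steps onto the sulfonyl sulfur show the nitrogen substituent does move the number, so a shift beyond the scatter is possible in either direction, and the direction is not settled by the data. For compound 4 a number somewhat above compound 3 is estimated, as a 2.2-fold higher number from compound 3 to compound 4 (0.33 log units; beyond the scatter), placing compound 4 at an expected 35 nM with a range from 8 nM to 150 nM.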

Compound 4, half-maximal effective concentration: 1.74 nM
The estimate for compound 4 lay 20-fold (1.30 log units) above the measured number, outside the stated range (below it).
By their numbers in this assay, from the lowest: compound 4; then compound 3; then compounds 1 and 2 (each within the scatter of the next).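

In this assay a ring on the sulfonamide nitrogen can now be read directly: phenyl in place of methyl gives a 9.3-fold lower number from compound 3 to compound 4 (0.97 log units; beyond the scatter) and places compound 4 lowest of the four, with its steps to all the others beyond the scatter. For the compounds shown here, exchanging the whole group on the sulfonyl sulfur gives a 32-fold lower number from compound 1 to compound 4 (1.51 log units; beyond the scatter) and a 63-fold lower number from compound 2 to compound 4 (1.80 log units; beyond the scatter) as the only large steps in the set, so this position can move the number much further than the small chain groups showed. Nothing on hand accounts for the effect of the phenyl at this place.

As far as these compounds go, it remains open whether benzyl or pyridyl on the same nitrogen reads like phenyl, and whether phenyl with hydrogen in place of the remaining methyl keeps the low number. Also open, from the compounds shown here alone, is how chloro or methoxy on the phenyl ring would move it.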